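The source may hold more compounds than are shown below. What is called first, only, known or untested is meant among the compounds shown, and "the series" means these compounds.

Three compounds with a shared core have been examined in an ADME assay on CCD 19Lu cells (Homo sapiens) for antiproliferative activity, read by MTT assay, with a stated time of 24 h; a lower number here means a stronger inhibitor, a higher number a weaker inhibitor. Compound 1 `Clc1ccc(-c2cc(-c3ccccc3)c3cc(Br)ccc3n2)cc1`, which carries a 4-chlorophenyl group, gives 528000 nM, the higher of the two numbers available. Compound 3 `COc1cc(-c2cc(-c3ccccc3)c3cc(Br)ccc3n2)cc(OC)c1OC` gives 105000 nM, lower by more than the usual scatter. Compound 2 `O=[N+]([O-])c1cccc(-c2cc(-c3ccccc3)c3cc(Br)ccc3n2)c1` has no number, and its result reads "not determined" (no result reported).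

Compound 4 `Brc1ccc2nc(-c3ccco3)cc(-c3ccccc3)c2c1` has not yet been measured. It has furan-2-yl in place of 4-chlorophenyl on an aromatic carbon, next to the ring nitrogen: furan-2-yl in place of 4-chlorophenyl on an aromatic carbon. Among the compounds with values here, no measured pair shows the effect of this exact swap, so the expectation rests on thin evidence. Within the data shown here, the one guide is compound 3, which has another group at that place and reads 105000 nM. A moderate move towards a lower number in this assay therefore seems more likely than a large one, though no change beyond the scatter is also possible. The expected change is a 2.4-fold lower number from compound 1 to compound 4 (0.38 log units; beyond the scatter). For compound 4 the estimated value is 220000 nM, with an expected range from 70000 nM to 600000 nM.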

Compound 4, half-maximal inhibitory concentration: 631000 nM
Estimate against measurement, compound 4: 2.9-fold (0.46 log units) below; measured number outside the range, above it.
By their numbers in this assay, from the lowest: compound 3; then compounds 1 and 4 (each within the scatter of the next).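

At the aromatic carbon next to the ring nitrogen, putting furan-2-yl in place of 4-chlorophenyl gives a 1.2-fold higher number from compound 1 to compound 4 (0.08 log units; within the scatter) in this assay. This pair shows that a five-membered aromatic ring with one hetero atom and a six-membered aromatic ring of carbon only cannot be told apart here, so the lower number of compound 3, 105000 nM, does not carry over to every other group at this place. Nothing measured here explains why compound 1 and compound 4 read alike.

Still open, as far as these compounds go, is how this position responds to a group that is not an aromatic ring, such as an amine, a carboxylic acid or a longer chain. The phenyl group stays the same in every compound shown, so its part in these numbers is also open.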